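Methylphenyl Replacement on a Cytotoxicity Series at Its Limits

The source may report more compounds than this note shows. Statements on the series, on what has been measured and on what is new or still open speak of the compounds shown alone.

Compound 3 `Cc1ccc2c(NCc3ccc(NC(=O)C4CCN(Cc5ccc(F)cc5Cl)CC4)cc3)nc(N(C)C)nc2c1` was tested in a functional assay on SV5A8 cells (Homo sapiens) for cytotoxicity (a lower number here means a stronger inhibitor, a higher number a weaker inhibitor), and in this assay compound 3 gives only a limit, > 5910 nM. Compound 1 `Cc1ccc2c(NCc3ccc(NC(=O)C4CCN(Cc5cc(Cl)ccn5)CC4)cc3)nc(N(C)C)nc2c1` likewise stops at a limit of > 5400 nM. Compound 2 `Cc1ccc2c(NCc3ccc(NC(=O)C4CCN(Cc5ncc[nH]5)CC4)cc3)nc(N(C)C)nc2c1` also reaches only a limit, > 20000 nM. Since all three values are limits, the steps a step that the two limits leave unreadable from compound 1 to compound 3, a step that the two limits leave unreadable from compound 2 to compound 3 and a step that the two limits leave unreadable from compound 1 to compound 2 have no readable size.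

Compound 4 `Cc1ccc(CN2CCC(C(=O)Nc3ccc(CNc4nc(N(C)C)nc5cc(C)ccc45)cc3)CC2)cc1` differs from compound 3 as follows: 4-methylphenyl in place of 2-chloro-4-fluorophenyl on a saturated chain carbon bound to an amine nitrogen in a ring. Within the data shown here, no measured step offers a readable size, so nothing points to a change the assay would register. Compound 4 is therefore expected to give about 9000 nM, within an estimated range of 3000 nM to 30000 nM, most likely again reported as a limit. That amounts to an expected step that the limit leaves unreadable from compound 3 to compound 4.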

Compound 4, half-maximal inhibitory concentration: > 4150 nM
Compound 4 gave a limit, no number; the forecaster's own chance of this, stated with the estimate: 80%; the middle value lies beyond the limit too.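

Compound 4 also gives only a limit, > 4150 nM, so its steps from compound 1, compound 2 and compound 3 cannot be read. The compounds shown leave open whether changing the group on the saturated chain carbon alters potency at all, as none of the four gives a number.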